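Replacing oxan-4-yl with 1,2-thiazol-4-yl: expected cytotoxicity

The source may hold more compounds than are shown below. What is called first, only, known or untested is meant among the compounds shown, and "the series" means these compounds.

Compound 1 `COc1nc(-c2ccc(C(F)(F)F)cc2)ccc1[C@@H](c1ccccc1)[C@@](O)(CCN(C)C)c1cccc2ccccc12`, compound 2 `COc1nc(-c2ccc(C#N)cc2)ccc1[C@@H](c1ccccc1)[C@@](O)(CCN(C)C)c1cccc2ccccc12` and compound 3 `COc1nc(C2CCOCC2)ccc1[C@@H](c1ccccc1)[C@@](O)(CCN(C)C)c1cccc2ccccc12` share one core and differ only in a single group. In a toxicity assay on Vero cells (Chlorocebus sabaeus) for cytotoxicity (a higher number here means that more compound is tolerated, a lower number that less compound is tolerated), compound 1 gives > 50 ug/mL, which is a limit of the assay rather than a number. Compound 2 reaches > 50 ug/mL, again a limit. Compound 3 also shows only a limit, > 50 ug/mL, so that (the limit of > 50 ug/mL in this assay, at which 3 of the 3 values shown sit). With every value a limit, the steps a step that the two limits leave unreadable from compound 1 to compound 2, a step that the two limits leave unreadable from compound 1 to compound 3 and a step that the two limits leave unreadable from compound 2 to compound 3 have no readable size. Compound 4 `COc1nc(-c2cnsc2)ccc1[C@@H](c1ccccc1)[C@@](O)(CCN(C)C)c1cccc2ccccc12` carries 1,2-thiazol-4-yl in place of oxan-4-yl on an aromatic carbon. Since exchanges at this group never moved a value off the limit, compound 4 is expected to stay near it as well. For compound 4 the expected value in this assay is 60 ug/mL, estimated between 25 ug/mL and 120 ug/mL. The step this estimate means, a step that the limit leaves unreadable from compound 3 to compound 4, is expected to lie within the scatter.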

Compound 4, half-maximal cytotoxic concentration: 26.3 ug/mL
Compound 4: the middle estimate sits 2.3-fold (0.36 log units) above what was measured; the range from low to high includes it.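

In this assay, for the compounds shown here, compound 4 gives 26.3 ug/mL as the first plain number at this position. The other compounds show only a limit: (the limit of > 50 ug/mL in this assay, at which 3 of the 4 values shown sit). The steps of an at least 1.9-fold lower number from compound 3 to compound 4 (0.27 log units; that floor lies within the scatter) and an at least 1.9-fold lower number from compound 2 to compound 4 (0.27 log units; that floor lies within the scatter) and an at least 1.9-fold lower number from compound 1 to compound 4 (0.27 log units; that floor lies within the scatter) are only floors, so this change may lower the tolerated amount, but that is not shown.

As far as these compounds go, the true values of compound 1, compound 2 and compound 3 stay open, and with them the real size of these steps. Also open, from the compounds shown here alone, is whether an amine or a carboxylic acid at this position would stay at the limit or give a plain number.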